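A few compounds are considered here, and "the series" means these few. Any claim that something is new, unique, unknown or untested is made for them only; others in the source may bear on it.

Series notes. Compound 1 `Cc1ccc(C(=O)Nc2cccc(-c3oc4cc(-c5ccc(F)cc5)ccc4c(=O)c3O)c2)cc1` is the reference point of the set. In a functional assay on HepG2 cells (Homo sapiens) for antiproliferative activity, read by CCK-8 assay, with a stated time of 72 h (a lower number here means a stronger inhibitor, a higher number a weaker inhibitor), compound 1 gives 2320 nM, the lowest number of the three measured. Compound 2 `Cc1cc(C(=O)Nc2cccc(-c3oc4cc(-c5ccc(F)cc5)ccc4c(=O)c3O)c2)ccc1F` gives 9540 nM in this assay, and compound 3 `O=C(Nc1cccc(-c2oc3cc(-c4ccc(F)cc4)ccc3c(=O)c2O)c1)c1cc(F)cc(F)c1` gives 4960 nM. Both measured steps away from compound 1 go the same way: a 4.1-fold higher number from compound 1 to compound 2 (0.61 log units; beyond the scatter), and a 2.1-fold higher number from compound 1 to compound 3 (0.33 log units; beyond the scatter). Between the two fluorinated amides the gap is small, a 1.9-fold lower number from compound 2 to compound 3 (0.28 log units; within the scatter).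

Compound 4 `N#Cc1ccc(C(=O)Nc2cccc(-c3oc4cc(-c5ccc(F)cc5)ccc4c(=O)c3O)c2)cc1` carries the change (cyano in place of methyl on an aromatic carbon). For the measured compounds named here, no measured pair shows exactly this substitution; the two steps that bear on it are those that exchange the 4-methylphenyl of compound 1 for another aryl group on the same carbonyl carbon, and both gave higher numbers. On that basis a modest rise in the number is expected for compound 4 in this assay, a 1.9-fold higher number from compound 1 to compound 4 (0.29 log units; within the scatter), with the step from compound 1 to compound 3 as the nearer guide. Compound 4 is estimated at 4500 nM, within a range of 1800 nM to 11000 nM.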

Compound 4, half-maximal inhibitory concentration: 7110 nM
The estimate for compound 4 lay 1.6-fold (0.20 log units) below the measured number; the range from low to high includes it.
By their numbers in this assay, from the lowest: compound 1; then compounds 3, 4 and 2 (each within the scatter of the next).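

Replacing methyl with cyano on the aromatic carbon para to a large group gives a 3.1-fold higher number from compound 1 to compound 4 (0.49 log units; beyond the scatter) in this assay, so a change of this one group on the 4-methylphenyl is enough to give up the lowest number held by compound 1, and all three aryl replacements now point the same way. The replacements themselves do not separate, with a 1.4-fold higher number from compound 3 to compound 4 (0.16 log units; within the scatter) and a 1.3-fold lower number from compound 2 to compound 4 (0.13 log units; within the scatter) both within the scatter, so the 4-cyanophenyl amide, which carries no fluorine, cannot be told apart from either fluorinated amide. Nothing measured here accounts for the step from methyl to cyano.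

Still open, as far as these compounds go, is whether the standing of compound 1 depends on the methyl itself, or whether an ethyl, a methoxy or an amine on the same carbon would match it. From the compounds shown here alone, how a carboxylic acid there would compare with compound 4 is also open.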